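Sulfonyl Back in Place of Phenylcarbamoyl: Compound 4

The source may hold more compounds than are shown below. What is called first, only, known or untested is meant among the compounds shown, and "the series" means these compounds.

Compound 1 `CC1(C)Oc2ccc(S(=O)(=O)c3ccccc3)cc2[C@@H](/N=C(\NC#N)Nc2ccc(Cl)cc2)[C@@H]1O` gives 500 nM in a functional assay (aorta) with Rattus norvegicus as the target; a lower number here means a stronger inhibitor, a higher number a weaker inhibitor. Compound 2 `CC1(C)Oc2ccc(S(=O)(=O)Nc3ccccc3)cc2[C@@H](/N=C(\NC#N)Nc2ccc(Cl)cc2)[C@@H]1O` gives 3300 nM in this assay, a 6.6-fold higher number from compound 1 to compound 2 (0.82 log units; beyond the scatter). Compound 3 `CC1(C)Oc2ccc(C(=O)Nc3ccccc3)cc2[C@@H](/N=C(\NC#N)Nc2ccc(Cl)cc2)[C@@H]1O` gives only a limit of this assay, > 100000 nM. Compound 3 thus stands at the limit of > 100000 nM in this assay, at which 1 of the 3 values shown sits, the weakest position among the three. The steps into it were an at least 200-fold higher number from compound 1 to compound 3 (2.30 log units; beyond the scatter) and an at least 30-fold higher number from compound 2 to compound 3 (1.48 log units; beyond the scatter). Compound 4 `C[C@@H]1CCC[C@H](C)N1S(=O)(=O)c1ccc2c(c1)[C@@H](/N=C(\NC#N)Nc1ccc(Cl)cc1)[C@H](O)C(C)(C)O2` carries the change ((2,6-dimethylpiperidin-1-yl)sulfonyl in place of phenylcarbamoyl on an aromatic carbon). Because an at least 200-fold higher number from compound 1 to compound 3 (2.30 log units; beyond the scatter) and an at least 30-fold higher number from compound 2 to compound 3 (1.48 log units; beyond the scatter) both accompanied the loss of a sulfonyl in this place, and compound 4 brings a sulfonyl back, a large fall is expected for compound 4, an at least 33-fold lower number from compound 3 to compound 4 (1.52 log units; beyond the scatter). Compound 4 is estimated at 3000 nM, within a range from 500 nM to 30000 nM.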

Compound 4, half-maximal inhibitory concentration: 500 nM
Compound 4: the middle estimate sits 6.0-fold (0.78 log units) above what was measured, within the range that was stated.
By their numbers in this assay, from the lowest: compounds 1 and 4 (each within the scatter of the next); then compound 2. At a limit, above all of these: compound 3.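

With 2,6-dimethylpiperidin-1-yl on the sulfonyl sulfur, a non-aromatic ring serves here as well as phenyl, with no change at the digits printed from compound 1 to compound 4 (within the scatter). The same group compares favourably with anilino, with a 6.6-fold lower number from compound 2 to compound 4 (0.82 log units; beyond the scatter), and restoring the sulfonyl in place of phenylcarbamoyl gives an at least 200-fold lower number from compound 3 to compound 4 (2.30 log units; beyond the scatter). That last step starts from a limit, not a number: the limit of > 100000 nM in this assay, at which 1 of the 4 values shown sits.

The compounds shown leave open what piperidin-1-yl without the two methyl groups, or morpholin-4-yl, would give on the sulfonyl sulfur. They also leave open whether the two defined stereocentres of the new group affect the result.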